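A few compounds are considered here, and "the series" means these few. Any claim that something is new, unique, unknown or untested is made for them only; others in the source may bear on it.

Three related compounds have numbers in a functional assay on MDA-MB-231 cells (Homo sapiens) for antiproliferative activity, read by MTT assay, with a stated time of 48 h; on this read-out lower numbers stand for stronger inhibition and higher numbers for weaker inhibition. There, compound 1 (`COC(=O)/C(=C/c1ccccc1)CN1C(=O)[C@@H](OC)[C@H]1c1ccc(Cl)cc1`) gives 15600 nM, compound 2 (`COC(=O)/C(=C/c1ccccc1)CN1C(=O)[C@@H](OC)[C@H]1c1ccccc1C(F)(F)F`) gives 17600 nM, and compound 3 (`COc1ccc(OC)c([C@@H]2[C@H](OC)C(=O)N2C/C(C#N)=C/c2ccccc2)c1`) gives 23400 nM. Compound 2 lies within the scatter of both others, so these numbers do not separate it from either. The next compound to be tested in this assay is compound 4 (`COC(=O)/C(=C/c1ccccc1)CN1C(=O)[C@@H](OC)[C@H]1c1ccc(Cl)cc1Cl`). It differs from compound 2 in one place, on a saturated ring carbon of a four-membered non-aromatic ring with 1 nitrogen, where 2,4-dichlorophenyl stands in place of 2-(trifluoromethyl)phenyl (2,4-dichlorophenyl in place of 2-(trifluoromethyl)phenyl on a saturated ring carbon). Within the data shown here, only one measured step touches this position: a 1.1-fold higher number from compound 1 to compound 2 (0.05 log units; within the scatter). That exchange of aryl groups left the number within the scatter, though it does not involve 2,4-dichlorophenyl itself, so the evidence is thin. No step beyond the scatter is therefore expected, and no direction can be claimed with confidence. The estimated change is a 1.1-fold lower number from compound 2 to compound 4 (0.03 log units; within the scatter). For compound 4, the expected value is 16500 nM, with an estimated range of 8500 nM to 32000 nM.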

Compound 4, half-maximal inhibitory concentration: 19000 nM
Beside the measured number, compound 4's estimate is 1.2-fold (0.06 log units) below it; the range from low to high includes it.
By their numbers in this assay, from the lowest: compounds 1, 2, 4 and 3 (each within the scatter of the next).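

In this assay, placing 2,4-dichlorophenyl on the saturated ring carbon in place of 2-(trifluoromethyl)phenyl gives a 1.1-fold higher number from compound 2 to compound 4 (0.03 log units; within the scatter), so this position now holds three aryl groups alongside the methyl ester with no step beyond the scatter. The result also adds the first change within a single aryl group: chloro in place of hydrogen on an aromatic carbon gives a 1.2-fold higher number from compound 1 to compound 4 (0.09 log units; within the scatter), which again lies within the scatter. The compounds shown come with no further measurement that bears on these results.

From the compounds shown here alone, whether an amine or a carboxylic acid on this aryl ring would give a step beyond the scatter remains open. Compound 3 differs from the other compounds in more than one place, so the compounds shown do not separate the effect of its aryl group from that of its nitrile.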